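This account rests on a few compounds, and the source may have more. Where it says the series, first, only, none or still open, it means among the compounds named here.

Measured compounds:
Compound 1, `NC1=NC2(CCSCC2)N(OCCCOc2ccc(Cl)c(Cl)c2)C(N)=N1`, gives 88.4% in an assay on isolated protein for inhibition of Dihydrofolate reductase (Homo sapiens), read by spectrophotometry, using NADPH, with stated times of 5 s and 6 min, tested at 5 uM; on this read-out higher numbers stand for a stronger effect at the one concentration tested and lower numbers for a weaker effect.
Compound 2, `NC1=NC2(CCOCC2)N(OCCCOc2ccccc2Cl)C(N)=N1`, gives 83.3% in this assay.
Compound 3, `NC1=NC2(CCSCC2)N(OCCCOc2cccc(Cl)c2Cl)C(N)=N1`, gives 83.8% in this assay.

On the numbers shown, compound 2 has the lowest of the three, but its gap to compound 3 and its gap to compound 1 are both within the usual scatter, so the three compounds cannot be told apart on these figures. Compound 4, `NC1=NC2(CCOCC2)N(OCCCOc2cccc(Cl)c2)C(N)=N1`, has not yet been measured. Compound 4 differs from compound 2 as follows: 3-chlorophenyl in place of 2-chlorophenyl on an oxygen on a saturated carbon. Among the measured compounds shown here, only one measured step speaks to a change in where the chlorine sits on the phenyl: a number 4.6 percentage points lower from compound 1 to compound 3 (within the scatter). That step was within the scatter. On this basis a change in chlorine placement on the phenyl, with the rest of the molecule held fixed, is expected to move this assay by no more than the scatter. For compound 4 the expected step is therefore a number 0.3 percentage points lower from compound 2 to compound 4 (within the scatter). The estimate for compound 4 is 83%, with a range from 70% to 92%.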

Compound 4, a percentage reported as inhibition, at one concentration (the size of the read-out at that concentration, not a potency): 83.2%
Beside the measured number, compound 4's estimate is 0.2 percentage points below it; the range from low to high includes it.
By their numbers in this assay, from the lowest: compounds 4, 2, 3 and 1 (each within the scatter of the next).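

In this assay, changing where the chlorine sits on the phenyl gives a number 0.1 percentage points lower from compound 2 to compound 4 (within the scatter). The only earlier change in chlorine placement involved two chlorines on the phenyl, a number 4.6 percentage points lower from compound 1 to compound 3 (within the scatter), so this is the first such reading for a single chlorine, and on a different core; among these compounds, neither change moves the read-out beyond the scatter. Nothing measured here offers an explanation for this result.

The compounds shown leave open whether an unsubstituted phenyl, a phenyl bearing a carboxylic acid or an amine, or a longer chain between the two oxygens would also stay within the scatter. Since each figure comes from a single concentration, they also leave open whether compound 2 and compound 4 differ in potency.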